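A 4-methoxyphenyl swap on compound 2

The source may hold more compounds than are shown below. What is called first, only, known or untested is meant among the compounds shown, and "the series" means these compounds.

In a functional assay on A549 cells (Homo sapiens) for cytotoxicity, read by MTT assay, with a stated time of 72 h (on this read-out higher numbers stand for weaker inhibition and lower numbers for stronger inhibition), compound 1 `O=C(N/N=C/c1ccc(F)cc1Cl)Nc1cc2c(Nc3ccc(F)c(Cl)c3)ncnc2cc1O[C@H]1CCOC1` gives 27200 nM and compound 2 `O=C(N/N=C/c1cccc(Cl)c1Cl)Nc1cc2c(Nc3ccc(F)c(Cl)c3)ncnc2cc1O[C@H]1CCOC1` gives 25000 nM. Among the compounds with values here, the two stand level, and compound 2 holds no real rank over its only measured neighbour. Compound 3 `COc1ccc(/C=N/NC(=O)Nc2cc3c(Nc4ccc(F)c(Cl)c4)ncnc3cc2O[C@H]2CCOC2)cc1` has not yet been measured. It carries 4-methoxyphenyl in place of 2,3-dichlorophenyl on a carbon with a double bond to nitrogen.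

Within the data shown here, only one measured step bears on this change, since it concerns the same place on the shared core. Exchanging 2-chloro-4-fluorophenyl for 2,3-dichlorophenyl gave a 1.1-fold lower number from compound 1 to compound 2 (0.04 log units; within the scatter). Among the measured compounds shown here, that step is a thin guide, as no measured compound carries 4-methoxyphenyl, and the data cannot show whether this group behaves like the two it follows. With no evidence for a direction, no shift beyond the scatter is expected, and the expected step is a 1.0-fold lower number from compound 2 to compound 3 (0.02 log units; within the scatter). Compound 3 is estimated at 24000 nM, with an expected range from 10000 nM to 55000 nM.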

Compound 3, half-maximal inhibitory concentration: 33100 nM
Estimate against measurement, compound 3: 1.4-fold (0.14 log units) below; measured number inside the range.
By their numbers in this assay, from the lowest: compounds 2, 1 and 3 (each within the scatter of the next).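

In this assay the move to 4-methoxyphenyl on a carbon with a double bond to nitrogen stays within the scatter, whether it is read from the 2,3-dichlorophenyl compound (a 1.3-fold higher number from compound 2 to compound 3 (0.12 log units; within the scatter)) or from the 2-chloro-4-fluorophenyl compound (a 1.2-fold higher number from compound 1 to compound 3 (0.09 log units; within the scatter)). The earlier pair compared only phenyl groups carrying halogens, whereas this change removes both chlorine atoms and brings in an oxygen and a hydrogen-bond acceptor at the same heavy-atom count, and the three compounds still stand level. Nothing measured here explains why these numbers stand level.

Going by these compounds, all three compounds carry a substituted phenyl at this place, so it remains open whether a group of another kind, such as a carboxylic acid, an amine or a longer alkyl chain, would produce a step beyond the scatter. Every step shown also lies at this one place, so the compounds do not tell whether a change elsewhere on the shared core would shift the number in this assay.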